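Compound 1 and an untested hydrogen swap

This account rests on a few compounds, and the source may have more. Where it says the series, first, only, none or still open, it means among the compounds named here.

Compound 1 `CN(Cc1cnc2nc(N)nc(NC(=O)OCc3ccc(B(O)O)cc3)c2n1)c1ccc(C(=O)N[C@@H](CCC(=O)O)C(=O)O)cc1`: 62.9 nM
Compound 2 `Nc1nc(N)c2nc(CN(Cc3ccc(B(O)O)cc3)c3ccc(C(=O)N[C@@H](CCC(=O)O)C(=O)O)cc3)cnc2n1`: "not determined" (no result reported)

In an ADME assay on HEK293 cells (Homo sapiens) for cytotoxicity, read by resazurin assay, with a stated time of 48 h, in the absence of a further agent (a lower number here means a stronger inhibitor, a higher number a weaker inhibitor), compound 1 gives 62.9 nM. Within the data shown here, this is the only number available, since compound 2 has no reported result, so compound 1 cannot be ranked against anything.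

Compound 3 `CN(Cc1cnc2nc(N)nc(NC(=O)OCc3ccccc3)c2n1)c1ccc(C(=O)N[C@@H](CCC(=O)O)C(=O)O)cc1` keeps the structure of compound 1 except at one place: a hydrogen atom in place of a group of 3 heavy atoms (1 boron, 2 oxygen; no ring), on an aromatic carbon. The swap sits on an aromatic carbon of a six-membered aromatic ring of carbon only, para to a large group.

Among the measured compounds shown here, no measured pair shows what such a swap does in this assay, so any forecast here is a judgement with wide margins. A weaker result, beyond the usual scatter, is the expectation, though little change remains possible. The expected move is a 4.8-fold higher number from compound 1 to compound 3 (0.68 log units; beyond the scatter). For compound 3 the estimated value is 300 nM, with an expected range of 60 nM to 3000 nM.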

Compound 3, half-maximal inhibitory concentration in the HEK293 assay: > 1000 nM
Compound 3 was reported as a limit (the forecaster's own chance of this, stated with the estimate: 15%); at least 3.3-fold (0.52 log units) between middle value and limit.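

In the HEK293 assay, compound 1 gives 62.9 nM, and putting a hydrogen atom in place of the group of 3 heavy atoms (1 boron, 2 oxygen) gives an at least 15-fold higher number from compound 1 to compound 3 (1.20 log units; beyond the scatter), the first sign that this aromatic carbon matters strongly for the cell result. The value of compound 3 there, > 1000 nM, is a limit of the assay. In a physicochemical assay for activation, read by HPLC, in phosphate buffer, with a stated time of 24 h, at pH 7.4 (a lower number here means that the compound disappears faster, a higher number that the compound lasts longer), compound 1 gives 0.29 h. In the physicochemical assay, compound 3 gives > 24 h, which is a limit of the assay. In the physicochemical assay, the same swap gives an at least 82-fold higher number from compound 1 to compound 3 (1.91 log units; beyond the scatter), a step that also rests on a limit for compound 3, so the compound that gives the lower number on cells is also the one that disappears faster.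

Going by these compounds, whether another group on this aromatic carbon, such as a carboxylic acid or an amine, would behave like the boron-bearing group remains open. A single pair also cannot tell whether the faster disappearance is what produces the lower number in the HEK293 assay.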